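Methyl to bromo in a three-compound inhibitor set

The compounds below may be only part of what the source reports. "The series", "measured", "known", "first", "only" and "open" are said of these compounds alone.

Compound 1 `O=C1/C(=C/c2ccccc2F)Cc2ccccc21`: 31700 nM
Compound 2 `O=C1/C(=C/c2ccccc2[N+](=O)[O-])Cc2ccccc21`: 740 nM
Compound 3 `Cc1ccccc1/C=C1\Cc2ccccc2C1=O`: 23900 nM

All three values come from a functional assay on P388 cells (Mus musculus) for inhibition; on this read-out lower numbers stand for stronger inhibition and higher numbers for weaker inhibition. Compound 3 gives 23900 nM, which places it close to one measured neighbour, a 1.3-fold lower number from compound 1 to compound 3 (0.12 log units; within the scatter), and far from the other, a 32-fold higher number from compound 2 to compound 3 (1.51 log units; beyond the scatter). The next compound, compound 4 `O=C1/C(=C/c2ccccc2Br)Cc2ccccc21`, has not yet been measured. It differs from compound 3 as follows: bromo in place of methyl on an aromatic carbon. In words, this is bromo in place of methyl on an aromatic carbon, ortho to a large group.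

Among the compounds with values here, no measured step makes this exact exchange, so the expectation rests on neighbouring ones. The closest guide is the exchange between fluoro and methyl, a 1.3-fold lower number from compound 1 to compound 3 (0.12 log units; within the scatter), which stays within the scatter. Compound 1, the other halogen-bearing compound, gives 31700 nM. The nitro steps are much larger, a 43-fold lower number from compound 1 to compound 2 (1.63 log units; beyond the scatter), and they show that a single exchange at this place can move the number strongly, so the range is kept wide. In this assay, no change beyond the scatter is expected, and the expected step is a 1.4-fold lower number from compound 3 to compound 4 (0.15 log units; within the scatter). Compound 4 is estimated at 17000 nM, with an expected range from 5000 nM to 45000 nM.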

Compound 4, half-maximal inhibitory concentration: > 50000 nM
Compound 4: a limit, no number (the forecaster's own chance of this, stated with the estimate: 5%); middle value at least 2.9-fold (0.46 log units) from the limit.
By their numbers in this assay, from the lowest: compound 2; then compounds 3 and 1 (each within the scatter of the next). At a limit, above all of these: compound 4.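

In this assay compound 4 stands at a limit of the assay and not at a number: the limit of > 50000 nM in this assay, at which 1 of the 4 values shown sits. This position had so far shown little movement between fluoro and methyl, a 1.3-fold lower number from compound 1 to compound 3 (0.12 log units; within the scatter), but bromo in place of methyl on an aromatic carbon, ortho to a large group, gives an at least 2.0-fold higher number from compound 3 to compound 4 (0.32 log units; beyond the scatter), so an exchange that does not involve nitro can also reach beyond the scatter here. The nitro compound remains far apart, with an at least 67-fold higher number from compound 2 to compound 4 (1.82 log units; beyond the scatter), whereas the floor of the other halogen pair, an at least 1.5-fold higher number from compound 1 to compound 4 (0.19 log units; that floor lies within the scatter), does not separate bromo from fluoro on this read-out.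

The compounds shown leave open whether the much lower number of compound 2 belongs to nitro alone or could also be reached at this place by another group, such as an amine, a nitrile or a carboxylic acid. As far as these compounds go, how far compound 4 lies past its limit also stays open, and with it the true size of its steps to compound 1 and compound 3.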